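Swapping a thiophene for a pyridine on a triazole core

A few compounds are considered here, and "the series" means these few. Any claim that something is new, unique, unknown or untested is made for them only; others in the source may bear on it.

Measured compounds:
compound 1 `CCc1ccc(-c2nc(CNc3ccc(C(=O)NO)cc3)n(-c3ccccc3)n2)cc1` 54.6%
compound 2 `O=C(NO)c1ccc(NCc2nc(-c3ccsc3)nn2-c2ccccc2)cc1` 53.4%
compound 3 `Cc1ccsc1-c1nc(CNc2ccc(C(=O)NO)cc2)n(-c2ccccc2)n1` 72.1%

In an assay on Sf9 cells for inhibition of protein deacetylase HDAC6 (Homo sapiens), read by fluorescence, with a stated time of 40 min, tested at 100 nM (a higher number here means more inhibition at the concentration tested (going by the name of the read-out), a lower number less inhibition), compound 3 gives 72.1% and holds the highest of the three numbers. The step of a number 17.5 percentage points higher from compound 1 to compound 3 (beyond the scatter) and the step of a number 18.7 percentage points higher from compound 2 to compound 3 (beyond the scatter) are both beyond the scatter, while the step of a number 1.2 percentage points lower from compound 1 to compound 2 (within the scatter) is within it, so the 3-methylthiophen-2-yl group stands out against its two neighbours.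

Compound 4 `O=C(NO)c1ccc(NCc2nc(-c3ccncc3)nn2-c2ccccc2)cc1` has not been measured. It differs from compound 3 in one place: pyridin-4-yl in place of 3-methylthiophen-2-yl on an aromatic carbon. The change sits on an aromatic carbon of a five-membered aromatic ring with 3 nitrogen, and it brings in a six-membered ring with one nitrogen.

The two measured steps that bear on this change point the same way: leaving the 3-methylthiophen-2-yl group for 4-ethylphenyl or for thiophen-3-yl cost a modest amount in this assay. A further exchange of that group is therefore expected to give back the gain, so a downward step of about the same size is estimated for compound 4, namely a number 22.1 percentage points lower from compound 3 to compound 4 (beyond the scatter).

The expected value for compound 4 is 50%, with a range from 32% to 68%.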

Compound 4, a percentage reported as inhibition, at one concentration (the size of the read-out at that concentration, not a potency): 30.8%
Estimate against measurement, compound 4: 19.2 percentage points above; measured number outside the range, below it.
By their numbers in this assay, from the lowest: compound 4; then compounds 2 and 1 (each within the scatter of the next); then compound 3.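

In this assay, the groups measured earlier at this position, on an aromatic carbon between two ring nitrogen atoms, gave no sign that the number could drop below the level of 4-ethylphenyl and thiophen-3-yl, but pyridin-4-yl falls beyond the scatter from both, with a number 23.8 percentage points lower from compound 1 to compound 4 (beyond the scatter) and a number 22.6 percentage points lower from compound 2 to compound 4 (beyond the scatter). The largest step of the set, a number 41.3 percentage points lower from compound 3 to compound 4 (beyond the scatter), comes although the leaving and entering groups match in heavy atoms, hydrogen-bond donors, hydrogen-bond acceptors and net charge, so those counts alone do not set the number at this position. Nothing shown here gives a measured reason for the low number of compound 4.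

A plain phenyl group would show whether the fall belongs to the ring nitrogen of pyridin-4-yl, and pyridin-3-yl or pyridin-2-yl would show whether the place of that nitrogen in the ring matters. Also open, on these data alone, is whether a 2-methylpyridin-4-yl group would regain any ground, and, as every number here comes from one concentration, how these steps would appear as potencies.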